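A few compounds are considered here, and "the series" means these few. Any claim that something is new, unique, unknown or untested is made for them only; others in the source may bear on it.

Series notes. Four compounds are in view: compound 1 `O=C(O)CO/N=C/c1ccc(Cl)cc1`, compound 2 `O=C(O)CO/N=C/c1ccc(Br)cc1`, compound 3 `C/C(=N\OCC(N)=O)c1ccc(Cl)cc1` and compound 4 `C/C(=N\OCC(N)=O)c1ccc(Br)cc1`. The first three have been run in a functional assay on the whole organism for inhibition, with Rattus norvegicus as the target, read by paw edema, with stated times of 1 h and 3 h; a higher number here means that more compound is needed for the effect, a lower number that less compound is needed; compound 4 has not.

In this assay compound 1 gives 45 mg/kg. In this assay compound 2 gives 46 mg/kg. These two differ in one place, (bromo in place of chloro on an aromatic carbon), and the step is a 1.0-fold higher number from compound 1 to compound 2 (0.01 log units; within the scatter). In this assay compound 3 gives 24 mg/kg. Against compound 1 and compound 2 this lies within the scatter, so no order among the three is drawn. The difference between the core of compound 3 and the core of compound 1 is not broken down here.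

Compound 4 relates to compound 3 as compound 2 relates to compound 1: bromo in place of chloro on an aromatic carbon. The surroundings of the place are not identical word for word: in compound 1 the carbon is para to a group of 7 heavy atoms, in compound 3 para to a group of 8 heavy atoms. The change is therefore the same kind of change, not the same. Across the compounds shown it occurs twice, once measured.

In this assay the expected step is a 1.0-fold higher number from compound 3 to compound 4 (0.02 log units; within the scatter), because a 1.0-fold higher number from compound 1 to compound 2 (0.01 log units; within the scatter) stayed within the scatter. Compound 4 is accordingly estimated at 25 mg/kg. For compound 4 the expected range runs from 15 mg/kg to 42 mg/kg. This rests on compound 1 and compound 2 alone.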

Compound 4, dose for half-maximal effect: 62 mg/kg
Estimate against measurement, compound 4: 2.5-fold (0.39 log units) below; the whole stated range lies below it.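

In this assay, bromo in place of chloro on an aromatic carbon now gives a 2.6-fold higher number from compound 3 to compound 4 (0.41 log units; beyond the scatter), while the same kind of change on the core of compound 1 stayed within the scatter, and the two steps set side by side read: the same change on two cores in this assay, a 1.0-fold higher number (0.01 log units; within the scatter) from compound 1 to compound 2 and a 2.6-fold higher number (0.41 log units; beyond the scatter) from compound 3 to compound 4, 2.5-fold (0.40 log units) apart, within the scatter of two such steps. For the compounds shown here, the gap between the steps therefore gives no ground for saying that the two cores respond differently to this change, even though only one of the two steps lies beyond the scatter. Equally, it does not show that the change carries over unaltered from one core to the other: each core contributes a single pair of compounds, so two steps can neither establish nor exclude a dependence on the core.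

The compounds shown leave open how fluoro, iodo or a nitrile on the same aromatic carbon would read in this assay, and whether a step of this size would recur there. They also leave open which of the differences between the core of compound 1 and the core of compound 3 bears on the step, and an ester or a longer chain in place of the groups at the far end of those cores would be one way to separate them.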